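A few compounds are considered here, and "the series" means these few. Any claim that something is new, unique, unknown or untested is made for them only; others in the source may bear on it.

Among the measured compounds shown here, compound 3 `N#Cc1ccc(OCc2ccncc2)cc1OC(C(=O)O)c1ccccc1Cl` gives 6 nM in an assay on A10 cells for antagonist activity at Endothelin-1 receptor (Rattus norvegicus) (on this read-out higher numbers stand for weaker inhibition and lower numbers for stronger inhibition), the lowest of the three numbers measured so far: compound 1 `N#Cc1ccc(OCc2ccsc2)cc1OC(C(=O)O)c1ccccc1Cl` gives 17 nM and compound 2 `N#Cc1ccc(OCc2ccsc2)cc1OC(C(=O)O)c1ccsc1` gives 630 nM in this assay. Compound 4 `N#Cc1ccc(OCc2ccc3ncoc3c2)cc1OC(C(=O)O)c1ccccc1Cl` differs from compound 3 by 1,3-benzoxazol-6-yl in place of pyridin-4-yl on a saturated chain carbon bound to an oxygen on an aromatic ring. For the measured compounds named here, only one measured step touches the same place: a 2.8-fold lower number from compound 1 to compound 3 (0.45 log units; beyond the scatter) was modest, whereas a 37-fold higher number from compound 1 to compound 2 (1.57 log units; beyond the scatter) concerns the other aryl group and carries less weight here. Exchanging one aromatic group for another at this position has so far moved the number by a modest amount, so a modest step in this assay is expected for compound 4, with no firm direction, as a 1.7-fold higher number from compound 3 to compound 4 (0.22 log units; within the scatter). Compound 4 is therefore estimated at 10 nM, within 3 nM to 40 nM.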

Compound 4, half-maximal inhibitory concentration: 9 nM
The estimate for compound 4 lay 1.1-fold (0.05 log units) above the measured number; the measured number falls inside the stated range.
By their numbers in this assay, from the lowest: compounds 3, 4 and 1 (each within the scatter of the next, the first and the last beyond it); then compound 2.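

In this assay, the larger 1,3-benzoxazol-6-yl, with its two fused aromatic rings, replaces the single rings at this place with little consequence: a 1.5-fold higher number from compound 3 to compound 4 (0.18 log units; within the scatter) and a 1.9-fold lower number from compound 1 to compound 4 (0.28 log units; within the scatter) are both steps within the scatter. The place on the saturated chain carbon bound to an oxygen on an aromatic ring therefore accepts a two-ring group, although pyridin-4-yl and thiophen-3-yl in compounds 3 and 1 remain separated beyond the scatter. Nothing shown gives a measured reason for this result.

As far as these compounds go, it remains open whether a group without an aromatic ring, such as an amine or a longer chain, would fit at this place. From the compounds shown here alone, it is also open whether 1,3-benzoxazol-6-yl would behave in the same way with thiophen-3-yl in place of 2-chlorophenyl on the carbon bearing the carboxylic acid.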